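Demethylation on the shared core: compound 1 to compound 4

The source may report more compounds than this note shows. Statements on the series, on what has been measured and on what is new or still open speak of the compounds shown alone.

Measured compounds:
- compound 1 `COc1ccc(C2=C(c3cc(OC)c(OC)c(OC)c3)C(=O)CC2O[SiH2]C(C)(C)C)cc1OC`: > 100 ug/mL
- compound 2 `C=CCOc1cc(C2=C(c3cc(OC)c(OC)c(OC)c3)C(=O)C(O)C2)ccc1OC`: > 100 ug/mL
- compound 3 `CCOC(=O)COc1ccc(C2=C(c3cc(OC)c(OC)c(OC)c3)C(=O)CC2O)cc1`: > 100 ug/mL

Notes on the series. In an ADME assay on PA-1 cells (Homo sapiens) for cytotoxicity, read by MTT assay, with a stated time of 72 h (a higher number here means a weaker inhibitor, a lower number a stronger inhibitor), compound 1 gives only a limit, > 100 ug/mL, not a number. Compound 2 likewise gives only a limit in this assay, > 100 ug/mL. Compound 3 also stops at a limit in this assay, > 100 ug/mL. So compound 1 stands nowhere in particular relative to the other two: every value shown sits at the limit of > 100 ug/mL in this assay, at which 3 of the 3 values shown sit, and no step between measured compounds can be read from them.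

The compound to be measured is compound 4 `COc1ccc(C2=C(c3cc(OC)c(OC)c(OC)c3)C(=O)CC2O[SiH2]C(C)(C)C)cc1O`. The change from compound 1 is hydrogen in place of methyl on an oxygen on an aromatic ring. Within the data shown here, nothing among the measured compounds speaks to this change, since all three sit at the same limit. The expectation is therefore no step beyond the scatter, and compound 4 is expected to remain at the limit in this assay. The estimated step is a step that the limit leaves unreadable from compound 1 to compound 4, expected to be nil. For compound 4 in this assay the estimate is 120 ug/mL, with a range from 40 ug/mL to 400 ug/mL, most likely reported again as a limit.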

Compound 4, half-maximal inhibitory concentration: 14 ug/mL
Beside the measured number, compound 4's estimate is 8.6-fold (0.93 log units) above it, and the stated range ends above it.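

Methoxy to hydroxy, turning the 3,4-dimethoxyphenyl group into 3-hydroxy-4-methoxyphenyl, is the first change in the series to bring a compound off the limit in this assay, with an at least 7.1-fold lower number from compound 1 to compound 4 (0.85 log units; beyond the scatter). The step is a least size and not a full size, since compound 1 holds a limit and not a number, so the true distance between the two compounds may be wider than printed. Compound 4 is now the only compound in the series with a readable number, which gives this single oxygen on the aromatic ring a clear role in the read-out and sets it apart from the rest of the set: the limit of > 100 ug/mL in this assay, at which 3 of the 4 values shown sit.

The compounds shown leave open whether the step belongs to the hydroxy group itself or only to the loss of the methyl, and what an amine or a fluorine in that same place would do. Also open, from the compounds shown here alone, is whether the same exchange on another methoxy group of compound 1 would bring a step of its own in this assay.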